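A few compounds are considered here, and "the series" means these few. Any claim that something is new, unique, unknown or untested is made for them only; others in the source may bear on it.

Working notes on the series, all in an ADME assay on microsomes from liver (Rattus norvegicus) for metabolic stability, read by LC-MS, using NADPH, with a stated time of 30 min, tested at 1 uM; on this read-out higher numbers stand for fast clearance and lower numbers for slow clearance. Compound 1 `Cc1cc2c(cn1)Oc1ccc(NC(=O)c3ccc(Cl)cn3)cc1[C@@]21COC(N)=N1` gives < 14 mL.min-1.g-1, which is a limit of the assay and not a number. Compound 2 `COc1cc2c(cn1)Oc1ccc(NC(=O)c3ccc(Cl)cn3)cc1[C@@]21COC(N)=N1` gives < 14 mL.min-1.g-1, again a limit. Compound 3 `NC1=N[C@@]2(CO1)c1cc(NC(=O)c3ccc(Cl)cn3)ccc1Oc1cnc(C3CC3)cc12` gives < 14 mL.min-1.g-1, also a limit, so its place in the series cannot be read as a number. All the evidence so far is the limit of < 14 mL.min-1.g-1 in this assay, at which 3 of the 3 values shown sit.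

Compound 4 `NC1=N[C@@]2(CO1)c1cc(NC(=O)c3ccc(Cl)cn3)ccc1Oc1cnc(C3CCOCC3)cc12` differs from compound 3 at one place: oxan-4-yl in place of cyclopropyl on an aromatic carbon. In words, this is oxan-4-yl in place of cyclopropyl on an aromatic carbon. Going by the values given here, the steps that bear on this change are a step that the two limits leave unreadable from compound 1 to compound 2, a step that the two limits leave unreadable from compound 1 to compound 3 and a step that the two limits leave unreadable from compound 2 to compound 3, and none of them has a readable size. No step beyond the usual scatter is therefore expected in this assay, and no direction is expected. The expected step is a step that the limit leaves unreadable from compound 3 to compound 4. For compound 4 the estimate is 11 mL.min-1.g-1, with an expected range of 5 mL.min-1.g-1 to 25 mL.min-1.g-1.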

Compound 4, intrinsic clearance in microsomes: 79 mL.min-1.g-1
For compound 4 the middle estimate is 7.2-fold (0.86 log units) below the measured one; measured number outside the range, above it.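

In this assay, this position gives its first readable change, so the group on this aromatic carbon next to the ring nitrogen can move the read-out well clear of the limit: oxan-4-yl in place of cyclopropyl gives an at least 5.6-fold higher number from compound 3 to compound 4 (0.75 log units; beyond the scatter), in place of methoxy an at least 5.6-fold higher number from compound 2 to compound 4 (0.75 log units; beyond the scatter), and in place of methyl an at least 5.6-fold higher number from compound 1 to compound 4 (0.75 log units; beyond the scatter). Methyl, methoxy and cyclopropyl therefore cannot be told apart here, whereas oxan-4-yl stands apart from all three. Compound 4 is the only one of the series shown that is not at the limit: the limit of < 14 mL.min-1.g-1 in this assay, at which 3 of the 4 values shown sit.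

The steps among compounds 1, 2 and 3 cannot be read, so no order among those three groups can be given. The compounds shown also do not separate the ring oxygen of oxan-4-yl from its larger ring; cyclohexyl at this position would be the direct comparison.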